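This account rests on a few compounds, and the source may have more. Where it says the series, first, only, none or still open, it means among the compounds named here.

Measured so far:
compound 1 `COc1ccc2cc(-c3nn[nH]n3)cnc2c1` — 5 mg/kg
compound 2 `COc1ccc2cc(C(=O)O)cnc2c1` — > 25 mg/kg

In a functional assay on the whole organism (strain Sprague-Dawley) for inhibition, with Rattus norvegicus as the target (on this read-out lower numbers stand for an effect already at smaller amounts and higher numbers for an effect only at larger amounts of compound), compound 1 gives 5 mg/kg. Compound 2 gives only a limit, > 25 mg/kg, and no number; this is the limit of > 25 mg/kg in this assay, at which 1 of the 2 values shown sits. Within the data shown here, the one measured step is an at least 5.0-fold higher number from compound 1 to compound 2 (0.69 log units; beyond the scatter), so compound 2 stands at the weak end of what has been measured, with only a bound to its name.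

Compound 3 `COc1ccc2c(O)c(C(=O)O)cnc2c1` is the next member. It differs from compound 2 by hydroxy in place of hydrogen on an aromatic carbon. Among the measured compounds shown here, no measured step concerns a hydroxy group; the single step seen concerns the exchange of carboxy for 2H-tetrazol-5-yl and does not carry over to this change. The expectation therefore rests on compound 2 alone. Compound 3 is expected to give 30 mg/kg, within 12 mg/kg to 100 mg/kg. The expected step is a step that the limit leaves unreadable from compound 2 to compound 3, with a real chance that this assay again reports only a limit.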

Compound 3, minimum effective dose: > 50 mg/kg
Compound 3 gave a limit, no number; the forecaster's own chance of this, stated with the estimate: 65%; middle value at least 1.6-fold (0.22 log units) away from the limit.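

Compound 2 stands only as a limit in this assay, > 25 mg/kg. Among these compounds, compound 3 likewise stands only as a limit, > 50 mg/kg, so no step between the two can be read. Going by these compounds, whether hydroxy in place of hydrogen on an aromatic carbon changes the effect at all, and in which direction, stays open.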